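The source may hold more compounds than are shown below. What is called first, only, known or untested is meant among the compounds shown, and "the series" means these compounds.

Of the compounds shown here, three built on a shared core have been tested in an ADME assay on HCT-116 cells (Homo sapiens) for cytotoxicity, read by MTT assay, with a stated time of 72 h; a lower number here means a stronger inhibitor, a higher number a weaker inhibitor. Compound 1 `CCCCCN1C(=O)C/C(=C\c2cccc(C(=O)Nc3ccc(C)cc3)c2)C1=O` gives in this assay only a limit of the assay and no number, > 100000 nM. Compound 2 `Cc1cccc(NC(=O)c2cccc(/C=C3\CC(=O)N(c4ccccc4)C3=O)c2)c1` likewise gives in this assay only a limit and no number, > 100000 nM. Compound 3 `CCOc1ccc(NC(=O)c2cccc(/C=C3\CC(=O)N(Cc4ccccc4)C3=O)c2)cc1` is the one of the three that gives a number in this assay, 41700 nM. Compound 2 therefore stands at the edge of what this assay reports; the same edge is described by the limit of > 100000 nM in this assay, at which 2 of the 3 values shown sit, and so compound 2 cannot be set in any order against compound 1, while compound 3 is the only one of the three with a value inside the range of the assay.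

Compound 4 `O=C(Nc1ccc(F)cc1)c1cccc(/C=C2\CC(=O)N(c3ccccc3)C2=O)c1` has not yet been measured in this assay. It differs from compound 2 in one place: 4-fluorophenyl in place of 3-methylphenyl on an amide-type nitrogen. Among the measured compounds shown here, no step between measured compounds covers such a change, so nothing measured tells how large a step to expect. Compound 4 is expected to give about 150000 nM in this assay, within a range from 40000 nM to 500000 nM. The step that the limit leaves unreadable from compound 2 to compound 4 that this estimate means is expected to be none beyond the scatter, and compound 4 is most likely to come back as a limit once more.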

Compound 4, half-maximal inhibitory concentration: > 100000 nM
Compound 4 gave a limit, no number (the forecaster's own chance of this, stated with the estimate: 75%); the middle value lies beyond the limit too.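

Compound 4 gives only a limit in this assay, as compound 2 does, so no size can be read for the change from 3-methylphenyl to 4-fluorophenyl on the amide-type nitrogen: the limit of > 100000 nM in this assay, at which 3 of the 4 values shown sit.

The compounds shown leave open which single change, if any, separates compound 3, the only one with a number, from the compounds at the limit.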